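A few compounds are considered here, and "the series" means these few. Any claim that something is new, unique, unknown or untested is made for them only; others in the source may bear on it.

Working notes on a urea series sharing one pyrazole-type core, assessed in a functional assay on ACHN cells (Homo sapiens) for inhibition, read by sulforhodamine B assay, with a stated time of 48 h, tested at 10 uM; a lower number here means a stronger effect, a higher number a weaker effect of the compound at the concentration tested.

Compound 2 `COc1cc(Cl)cc(-c2nn(-c3cccc(NC(=O)Nc4ccc(Cl)c(C(F)(F)F)c4)c3)cc2-c2ccncc2)c1` gives 8.78% in this assay . Compound 1 `O=C(Nc1cccc(-n2cc(-c3ccncc3)c(-c3cc(O)cc(Cl)c3)n2)c1)Nc1ccc(Cl)c(Cl)c1` gives 6.85% in this assay , and the two numbers lie within the usual scatter of each other, so neither can be set above the other; both sit at the low end of the scale, meaning a strong effect at the concentration tested. Among the two measured compounds, compound 2 is the one whose number is nominally higher, but that difference is not one to read anything into.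

Compound 3 `COc1cc(Cl)cc(-c2nn(-c3cccc(NC(=O)Nc4ccc(Cl)c(Cl)c4)c3)cc2-c2ccncc2)c1` is not yet measured. It differs from compound 2 by a single exchange: chloro in place of trifluoromethyl on an aromatic carbon. Among the measured compounds shown here, compound 3 also carries the 3,4-dichlorophenyl urea seen in compound 1, which gave 6.85%, though the two differ elsewhere and no step between them is available.

Given that both measured compounds sit close together, the expected step of a number 0.8 percentage points lower from compound 2 to compound 3 (within the scatter) in this assay is small, with no change beyond the scatter in either direction. Compound 3 is therefore estimated at 8% in this assay , expected between 1% and 20%.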

Compound 3, a percentage reported as activity, at one concentration (the size of the read-out at that concentration, not a potency): 9.65%
Estimate against measurement, compound 3: 1.7 percentage points below; measured number inside the range.
By their numbers in this assay, from the lowest: compounds 1, 2 and 3 (each within the scatter of the next).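

In this assay, chloro in place of trifluoromethyl on an aromatic carbon, ortho to a chloro group, gives a number 0.9 percentage points higher from compound 2 to compound 3 (within the scatter), so the two groups cannot be told apart at this position at the concentration tested. Compound 3 also supplies a second single-place comparison, at a different site: methyl in place of hydrogen on an oxygen on an aromatic ring gives a number 2.8 percentage points higher from compound 1 to compound 3 (within the scatter), so the earlier pair, which differed in two places, now resolves into two steps that each stay within the scatter. No measurement is available that bears on either step, and the series offers no account of them.

From the compounds shown here alone, all three compounds were read at a single concentration, which gives the size of the effect and not a potency, so differences that might appear at lower concentrations remain open. Also open, going by these compounds, is whether the effect holds with a carboxylic acid or an amine on the aromatic ring in place of the chloro or trifluoromethyl group, or with a longer chain such as ethyl or propyl on the oxygen.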